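This account rests on a few compounds, and the source may have more. Where it says the series, first, only, none or still open, it means among the compounds named here.

Measured in a functional assay on A549 cells (Homo sapiens) for antiproliferative activity, read by MTT assay, with a stated time of 72 h; a lower number here means a stronger inhibitor, a higher number a weaker inhibitor:
- Compound 1 `COc1cccc(N2C(=O)COc3ccc(-c4cnc(Cl)c(NS(=O)(=O)c5ccc(F)cc5)c4)cc32)c1`: 32700 nM
- Compound 2 `COc1ccc(N2C(=O)COc3ccc(-c4ccc(O)cc4)cc32)cc1`: > 40000 nM, a limit of the assay
- Compound 3 `COc1cccc(N2C(=O)COc3ccc(-c4cnc(OC)c(NS(=O)(=O)c5ccc(F)cc5)c4)cc32)c1`: 11200 nM

Of the two compounds with actual numbers, compound 1 stands higher, at 32700 nM, which makes it the weaker of the pair. For the measured compounds named here, the only measured step is a 2.9-fold lower number from compound 1 to compound 3 (0.47 log units; beyond the scatter), with methoxy in place of chloro on an aromatic carbon. Going by the values given here, compound 2 differs from compound 1 in more than one place, and its value is only a limit, so it gives no step.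

Compound 4 `Cc1ccc(N2C(=O)COc3ccc(-c4cnc(Cl)c(NS(=O)(=O)c5ccc(F)cc5)c4)cc32)cc1` keeps the chloro group of compound 1 and changes a different place: 4-methylphenyl in place of 3-methoxyphenyl on an amide-type nitrogen in a ring. This is 4-methylphenyl in place of 3-methoxyphenyl on an amide-type nitrogen in a ring. Among the compounds with values here, no measured step covers this change. The modest step to compound 3, a 2.9-fold lower number from compound 1 to compound 3 (0.47 log units; beyond the scatter), serves only as a rough guide to how far a single change has moved the number in this series. No step beyond the scatter is therefore expected in this assay, and no direction can be favoured.

For compound 4 the estimated value is 30000 nM, with an expected range from 13000 nM to 50000 nM. This estimate means an expected 1.1-fold lower number from compound 1 to compound 4 (0.04 log units; within the scatter).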

Compound 4, half-maximal inhibitory concentration: 30900 nM
Estimate against measurement, compound 4: 1.0-fold (0.01 log units) below; low and high end bracket the measured number.
By their numbers in this assay, from the lowest: compound 3; then compounds 4 and 1 (each within the scatter of the next). At a limit, above all of these: compound 2.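

In this assay, for the compounds shown here, the first look at the group on the amide-type nitrogen in a ring gives a 1.1-fold lower number from compound 1 to compound 4 (0.02 log units; within the scatter), so in this pair the two compounds cannot be told apart. Going by these compounds alone, the entering 4-methylphenyl carries no oxygen where the leaving 3-methoxyphenyl does, and its substituent also stands at a different place on the phenyl ring, yet this double difference leaves the two numbers within the scatter of each other; the one pair cannot show whether either difference alone would matter. Within the data shown here, the only step beyond the scatter so far therefore remains the one at the other place, with methoxy in place of chloro, a 2.9-fold lower number from compound 1 to compound 3 (0.47 log units; beyond the scatter).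

Compound 2 is held at a limit of the assay and gives no number to compare: the limit of > 40000 nM in this assay, at which 1 of the 4 values shown sits. As far as these compounds go, it remains open whether 4-methylphenyl would read the same alongside the methoxy group of compound 3, and whether an amine or a carboxylic acid on the phenyl ring at this nitrogen would move the number at all.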